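The source may hold more compounds than are shown below. What is called first, only, known or untested is meant among the compounds shown, and "the series" means these compounds.

Measured so far:
compound 1 `Brc1cccc2ccn(CCN3CCN4CCCCC4C3)c12` — 13%
compound 2 `CN1CCCN(CCn2ccc3ccc(Cl)cc32)CC1` — 85%

Compound 2 stands highest of the two numbers in an assay on HEK293 cells for binding affinity to 5-hydroxytryptamine receptor 7 (Homo sapiens), read by radioligand binding, tested at 1 uM; a lower number here means less inhibition, a higher number more inhibition at the concentration tested (going by the name of the read-out); its nearest neighbour, compound 1, lies far lower, a gap well beyond the scatter. Among the measured compounds shown here, no two measured compounds differ in only one place, so the series offers no single-change step to calibrate against. Compound 3 `Cc1ccc2ccn(CCN3CCCN(C)CC3)c2c1` differs from compound 2 by methyl in place of chloro on an aromatic carbon. Both the leaving and the entering group count one heavy atom, carry no hydrogen-bond donor or acceptor and no charge, so by the counted features the change is small. In this assay a modest downward step is expected, one that may not clear the scatter. The expected step is a number 13 percentage points lower from compound 2 to compound 3 (beyond the scatter). Compound 3 is estimated to give about 72%, with a range from 48% to 90%.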

Compound 3, a percentage reported as inhibition, at one concentration (the size of the read-out at that concentration, not a potency): 62%
Beside the measured number, compound 3's estimate is 10 percentage points above it, within the range that was stated.
By their numbers in this assay, from the lowest: compound 1; then compound 3; then compound 2.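

In this assay, among the compounds shown here, the change from chloro to methyl on this aromatic carbon gives the first single-change step: a number 23 percentage points lower from compound 2 to compound 3 (beyond the scatter). The position is therefore not indifferent to the group it carries, even though the leaving and entering groups each count one heavy atom and neither has a hydrogen-bond donor, a hydrogen-bond acceptor or a net charge. Compound 3 still gives 62%, so inhibition at the concentration tested persists with methyl at this carbon.

Nothing available accounts for the size of this step. As far as these compounds go, it remains open how fluoro, methoxy or an amine would read at this carbon, and whether the same exchange elsewhere on the six-membered ring would give a step of similar size.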